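This account rests on a few compounds, and the source may have more. Where it says the series, first, only, none or still open, it means among the compounds named here.

Measured so far:
Compound 1, `[O-][S+](Cc1ccccc1)c1nnc(-c2ccccc2O)o1`: in a functional assay on HUVEC cells (Homo sapiens) for inhibition, read by ELISA (on this read-out higher numbers stand for weaker inhibition and lower numbers for stronger inhibition), compound 1 gives 6000 nM.
Compound 2, `[O-][S+](Cc1ccccc1)c1nnc(-c2cccnc2)o1`: in this assay compound 2 gives 6000 nM.

Compound 2 stands level with compound 1 at the digits shown, and the step between them is no change at the digits printed from compound 1 to compound 2 (within the scatter), so the two cannot be told apart on this read-out. Both sit at a weak level of inhibition.

Compound 3, `[O-][S+](Cc1ccccc1)c1nnc(-c2ccccn2)o1`, has not yet been measured. It differs from compound 2 in a single place: pyridin-2-yl in place of pyridin-3-yl on an aromatic carbon. The two have the same atoms, joined differently.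

Within the data shown here, only one measured step is available for comparison, and it concerns a larger change at the same aromatic carbon: replacing 2-hydroxyphenyl by pyridin-3-yl left the number unchanged within the scatter. That gives no sign that the group on this aromatic carbon moves the read-out, though a single step is thin evidence and the present change is a smaller one.

On that basis compound 3 is expected to give 6000 nM in this assay, with a range from 2000 nM to 18000 nM. The expected step for compound 3 is therefore no change at the digits printed from compound 2 to compound 3 (within the scatter), none beyond the scatter.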

Compound 3, half-maximal inhibitory concentration: 4000 nM
For compound 3 the middle estimate is 1.5-fold (0.18 log units) above the measured one, and the stated range covers the measured number.
By their numbers in this assay, from the lowest: compounds 3, 1 and 2 (each within the scatter of the next).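

In this assay the swap of pyridin-3-yl for pyridin-2-yl gives a 1.5-fold lower number from compound 2 to compound 3 (0.18 log units; within the scatter), so moving the nitrogen within this six-membered aromatic ring, with the atoms themselves unchanged, cannot be told apart from no effect on this read-out. Replacing 2-hydroxyphenyl with pyridin-2-yl gives a 1.5-fold lower number from compound 1 to compound 3 (0.18 log units; within the scatter), which means that three different groups on this aromatic carbon now lie within the scatter of one another, where earlier only two could be compared. Nothing measured here offers an explanation for these numbers.

Going by these compounds, all three groups at this carbon are six-membered aromatic rings, so it remains open whether something quite different there, such as an amine, a carboxylic acid or a longer alkyl chain, would shift the number beyond the scatter. On these data alone, the group of 9 heavy atoms on the other side of the five-membered ring is the same in all three compounds, so what a change to that part would do is also open.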